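The source may report more compounds than this note shows. Statements on the series, on what has been measured and on what is new or still open speak of the compounds shown alone.

Working notes on the series

Three analogues share one core and differ only at the saturated ring carbon. Compound 1 `CCC1C(=O)N(C)c2cnc(Nc3ccc(S(N)(=O)=O)cc3)nc2N1C` carries an ethyl there and gives 479 nM in an assay on Sf9 cells for inhibition of serine/threonine-protein kinase 4 (Homo sapiens), read by luminescence and ADP-Glo, with a stated time of 1 h, in the presence of a further agent that is not named here; on this read-out lower numbers stand for stronger inhibition and higher numbers for weaker inhibition. Compound 2 `CN1C(=O)C(c2cccc(F)c2)N(C)c2nc(Nc3ccc(S(N)(=O)=O)cc3)ncc21` carries a 3-fluorophenyl and gives 134 nM; compound 3 `CN1C(=O)C(c2ccccc2Br)N(C)c2nc(Nc3ccc(S(N)(=O)=O)cc3)ncc21` carries a 2-bromophenyl and gives 57 nM. Compound 3 has the lowest number of the three: the step to it is an 8.4-fold lower number from compound 1 to compound 3 (0.92 log units; beyond the scatter) and a 2.4-fold lower number from compound 2 to compound 3 (0.37 log units; beyond the scatter), while the aryl-for-ethyl step a 3.6-fold lower number from compound 1 to compound 2 (0.55 log units; beyond the scatter) is smaller.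

Compound 4 `Cc1ccc(F)cc1C1C(=O)N(C)c2cnc(Nc3ccc(S(N)(=O)=O)cc3)nc2N1C` is not yet measured. Its change from compound 3 is 5-fluoro-2-methylphenyl in place of 2-bromophenyl on a saturated ring carbon. Among the measured compounds shown here, the only aryl-to-aryl comparison at hand is the step from compound 2 to compound 3, and it is modest; the change to compound 4 keeps an aryl group at the same carbon, so no step beyond the scatter is expected in either direction, with a slight lean toward a higher number. Compound 4 is expected to give about 85 nM (range 35 nM to 200 nM), a step of a 1.5-fold higher number from compound 3 to compound 4 (0.17 log units; within the scatter).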

Compound 4, half-maximal inhibitory concentration: 168 nM
Estimate against measurement, compound 4: 2.0-fold (0.30 log units) below; low and high end bracket the measured number.
By their numbers in this assay, from the lowest: compound 3; then compounds 2 and 4 (each within the scatter of the next); then compound 1.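

The 5-fluoro-2-methylphenyl group does not hold the level of the 2-bromophenyl group at this saturated ring carbon: the change gives a 2.9-fold higher number from compound 3 to compound 4 (0.47 log units; beyond the scatter), so a substituent on the aryl ring can separate two aryl analogues by more than the scatter. The advantage of an aryl group over ethyl survives in this analogue, with a 2.9-fold lower number from compound 1 to compound 4 (0.46 log units; beyond the scatter). Methyl in place of hydrogen on an aromatic carbon gives a 1.3-fold higher number from compound 2 to compound 4 (0.10 log units; within the scatter), so this methyl does not separate the two fluorinated aryl analogues.

Nothing shown gives a reason for these steps. As far as these compounds go, it remains open whether the bromine itself sets compound 3 apart, which 2-chlorophenyl or unsubstituted phenyl would test, and how a carboxylic acid or an amine on the aryl ring would read.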